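The compounds below may be only part of what the source reports. "The series", "measured", "known", "first", "only" and "open" are said of these compounds alone.

Working notes on the series. Compound 1 `OC[C@H]1O[C@@H](n2cnc3c(NCc4ccc(Cl)c(Cl)c4)ncnc32)[C@H](O)[C@@H]1O` carries a 3,4-dichlorobenzyl group on the shared core. In a functional assay on B16 cells (Mus musculus) for antiproliferative activity, with a stated time of 72 h (on this read-out higher numbers stand for weaker inhibition and lower numbers for stronger inhibition), compound 1 gives only a limit of the assay, > 166000 nM, and no number. Compound 2 `OC[C@H]1O[C@@H](n2cnc3c(NCc4cc(F)cc(F)c4)ncnc32)C(O)C1O` is the second measured member of the set. In this assay compound 2 likewise returns only a limit, > 166000 nM. Where compound 1 stands on the numbers shown is therefore fixed by the limit of > 166000 nM in this assay, at which 2 of the 2 values shown sit, so no step between measured compounds can be drawn from these two values, and no ordering of the two is possible. Compound 3 `Cc1ccc(O)c(CNc2ncnc3c2ncn3[C@@H]2O[C@H](CO)[C@@H](O)[C@H]2O)c1` is the next member to be measured. It differs from compound 1 in one place: 2-hydroxy-5-methylphenyl in place of 3,4-dichlorophenyl on a saturated chain carbon bound to a nitrogen on an aromatic ring. Nothing measured in the series reaches a number below the limit, so no direction for this change can be read from the two values shown. The expectation for compound 3 is that this assay again reports a limit rather than a number, with the step from compound 1 to compound 3 estimated as a number no higher from compound 1 to compound 3 (the limit leaves the size open). On that basis compound 3 is estimated at 166000 nM, within a range from 50000 nM to 500000 nM.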

Compound 3, half-maximal inhibitory concentration: > 166000 nM
Compound 3 was reported as a limit; the forecaster's own chance of this, stated with the estimate: 85%; the middle value lies on the limit itself.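

Compound 3 is again reported only as a limit in this assay, so no step can be read between compound 1 and compound 3: the limit of > 166000 nM in this assay, at which 3 of the 3 values shown sit. The compounds shown leave open whether 2-hydroxy-5-methylphenyl in place of 3,4-dichlorophenyl changes antiproliferative activity at all, and in which direction.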